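The source may hold more compounds than are shown below. What is called first, only, known or untested is meant among the compounds shown, and "the series" means these compounds.

Measured so far:
- Compound 1 `CC[S+]([O-])c1ccccc1Nc1nc(Nc2ccc(N3CCN(C)CC3)cc2OC)ncc1Cl`: 35.2 nM
- Compound 2 `CC[S+]([O-])c1cc(F)ccc1Nc1nc(Nc2ccc(N3CCCN(C)CC3)cc2OC)ncc1Cl`: 64.5 nM
- Compound 3 `CCSc1ccccc1Nc1nc(Nc2ccc(N3CCN(C)CC3)cc2OC)ncc1Cl`: 981 nM

In a functional assay on NCI-H2228 cells (Homo sapiens) for inhibition, read by CCK-8 assay (a higher number here means a weaker inhibitor, a lower number a stronger inhibitor), compound 3 gives the highest number of the three, with compound 2 the nearest and compound 1 the furthest below it. Compound 4 `CC[S+]([O-])c1cc(Cl)ccc1Nc1nc(Nc2ccc(N3CCN(C)CC3)cc2OC)ncc1Cl` differs from compound 3 by a group of 11 heavy atoms (8 carbon, 1 oxygen, 1 sulfur, 1 chlorine; one six-membered aromatic ring of carbon only) in place of a group of 9 heavy atoms (8 carbon, 1 sulfur; one six-membered aromatic ring of carbon only), on a nitrogen on an aromatic ring. Going by the values given here, the only measured step that bears on this is a 28-fold higher number from compound 1 to compound 3 (1.45 log units; beyond the scatter); compound 4 carries the oxygen counted in the entering group, so the reverse of that step is expected. Compound 2, which also carries oxygen and a halogen on that ring, sits within scatter of compound 1. Compound 4 is therefore estimated at 40 nM, with a range from 15 nM to 110 nM. The expected step is a 25-fold lower number from compound 3 to compound 4 (1.39 log units; beyond the scatter).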

Compound 4, half-maximal inhibitory concentration: 134 nM
For compound 4 the middle estimate is 3.4-fold (0.53 log units) below the measured one; measured number above the stated range.
By their numbers in this assay, from the lowest: compounds 1 and 2 (each within the scatter of the next); then compound 4; then compound 3.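

In this assay, chloro in place of hydrogen on an aromatic carbon is not neutral, giving a 3.8-fold higher number from compound 1 to compound 4 (0.58 log units; beyond the scatter) on a compound that already carries the oxygen. The chloro-bearing group still improves on 2-(ethylsulfanyl)phenyl, with a 7.3-fold lower number from compound 3 to compound 4 (0.86 log units; beyond the scatter), so the oxygen's gain survives the added chloro only in part. Nothing available explains the loss from chloro.

Open, going by these compounds, is whether a nitrile or a methyl on that same aromatic carbon would stay closer to compound 1 than chloro does.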